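From 4-fluorophenyl to 4-chlorophenyl: a growth inhibition estimate

The compounds below may be only part of what the source reports. "The series", "measured", "known", "first", "only" and "open" are said of these compounds alone.

- Compound 1 `Cn1cc(C2CC(c3ccccc3)=NN2C(=O)c2cccnc2)c2cc(Br)ccc21` gives 1520 nM
- Compound 2 `Cn1cc(C2CC(c3ccc(F)cc3)=NN2C(=O)c2cccnc2)c2cc(Br)ccc21` gives 480 nM

Both values come from a functional assay on MCF7 cells (Homo sapiens) for inhibition, read by MTT assay, with a stated time of 48 h; a higher number here means a weaker inhibitor of growth, a lower number a stronger inhibitor of growth. Compound 2 has the lower of the two numbers, so it is the stronger inhibitor of growth so far. The next compound, compound 3 `Cn1cc(C2CC(c3ccc(Cl)cc3)=NN2C(=O)c2cccnc2)c2cc(Br)ccc21`, carries chloro in place of fluoro on an aromatic carbon on the same shared core.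

Among the measured compounds shown here, only one measured step bears on this change. Fluoro in place of hydrogen on an aromatic carbon gave a 3.2-fold lower number from compound 1 to compound 2 (0.50 log units; beyond the scatter), a modest step beyond the scatter. For the measured compounds named here, no measured step replaces fluoro with another group, so the direction is uncertain, and a step smaller than that one is expected in this assay. The estimated change is a 1.1-fold lower number from compound 2 to compound 3 (0.06 log units; within the scatter) and may not exceed the scatter. Compound 3 is expected at 420 nM, with an estimated range of 170 nM to 1050 nM.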

Compound 3, concentration for 50% growth inhibition: 8100 nM
The estimate for compound 3 lay 19-fold (1.29 log units) below the measured number; measured number outside the range, above it.
By their numbers in this assay, from the lowest: compound 2; then compound 1; then compound 3.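

At this place on the aromatic ring, the choice of halogen matters much more than compound 2 alone could suggest: in this assay, chloro in place of fluoro gives a 17-fold higher number from compound 2 to compound 3 (1.23 log units; beyond the scatter). Adding a halogen here therefore does not by itself strengthen growth inhibition, since fluoro in place of hydrogen gave a 3.2-fold lower number from compound 1 to compound 2 (0.50 log units; beyond the scatter), whereas chloro in place of hydrogen gives a 5.3-fold higher number from compound 1 to compound 3 (0.73 log units; beyond the scatter), so the two changes run in opposite directions and compound 3 has the highest number of the three. Nothing available here accounts for this split between two groups of a single heavy atom each. The compounds shown leave open whether a methyl group, a methoxy group or an amine at this same place would track fluoro or chloro. They also leave open whether the same split would appear on a core without the bromo group.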